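Three chloromethylbenzyl purines and a fourth awaiting its number

The source may report more compounds than this note shows. Statements on the series, on what has been measured and on what is new or still open speak of the compounds shown alone.

Three compounds share a purine-type core bearing a chloromethylbenzyl group: compound 1 `ClCc1cccc(Cn2cnc3c(Cl)nc(Cl)nc32)c1`, compound 2 `Nc1nc(Cl)c2ncn(Cc3ccccc3CCl)c2n1` and compound 3 `ClCc1cccc(Cn2cnc3nc(Cl)nc(Cl)c32)c1`. In a functional assay on UACC-62 cells (Homo sapiens) for cytotoxicity, read by sulforhodamine B assay, with a stated time of 48 h (on this read-out lower numbers stand for higher toxicity in this test and higher numbers for lower toxicity in this test), compound 1 gives 6450 nM, compound 2 gives 8510 nM and compound 3 gives 4670 nM. Compound 3 has the lowest of the three numbers, yet both neighbours lie within the scatter of it, so no order among the three can be claimed. Compound 4 `ClCc1cccc(Cn2cnc3ncnc(Cl)c32)c1` differs from compound 3 by one change: hydrogen in place of chloro on an aromatic carbon. Among the measured compounds shown here, with no measured pair showing the effect of such a change, the step from compound 3 to compound 4 in this assay is expected to be small, a 1.5-fold higher number from compound 3 to compound 4 (0.18 log units; within the scatter), perhaps not beyond the scatter. Compound 4 is therefore estimated at 7000 nM, with a range from 2800 nM to 17500 nM.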

Compound 4, concentration lethal to 50% of the cells: 38900 nM
The estimate for compound 4 lay 5.6-fold (0.74 log units) below the measured number, outside the stated range (above it).
By their numbers in this assay, from the lowest: compounds 3, 1 and 2 (each within the scatter of the next); then compound 4.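

In this assay the chloro on the aromatic carbon between two ring nitrogen atoms proves not to be interchangeable with hydrogen: the change gives an 8.3-fold higher number from compound 3 to compound 4 (0.92 log units; beyond the scatter) and is the only step shown here that can be read. Compound 4 keeps the other chloro and the chloromethylbenzyl group, so this one change alone separates it from compound 3. Nothing available explains the size of this step. As far as these compounds go, whether a fluoro or a methoxy group at this position would keep the number near that of compound 3 remains open.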